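Methoxy in place of hydrogen on a cytotoxicity series

The compounds below may be only part of what the source reports. "The series", "measured", "known", "first", "only" and "open" are said of these compounds alone.

Compound 1 `Cc1nc(Nc2ccc(Cl)cc2)sc1C(=O)/C=C/c1ccccc1` sits at the limit of a functional assay on NCI-H460 cells (Homo sapiens) for cytotoxicity, read by MTT assay; on this read-out higher numbers stand for weaker inhibition and lower numbers for stronger inhibition: in this assay compound 1 gives > 25000 nM, a limit rather than a number. Compound 2 `COc1cccc(/C=C/C(=O)c2sc(Nc3cccc(C)c3)nc2C)c1` likewise gives only a limit, > 25000 nM. Both values rest at the limit of > 25000 nM in this assay, at which 2 of the 2 values shown sit, so compound 1 cannot be ranked against compound 2. Compound 3 `COc1cccc(/C=C/C(=O)c2sc(Nc3ccc(Cl)cc3)nc2C)c1` differs from compound 1 by methoxy in place of hydrogen on an aromatic carbon. For the measured compounds named here, no step between measured compounds is available; the change is expected to give none beyond the scatter, a step that the limit leaves unreadable from compound 1 to compound 3. Compound 3 is estimated at 30000 nM, in the range 10000 nM to 100000 nM, and is expected most probably to be reported again only as a limit.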

Compound 3, half-maximal inhibitory concentration: > 25000 nM
Compound 3: no number, only a limit (the forecaster's own chance of this, stated with the estimate: 85%); the middle value lies beyond the limit too.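

No step can be read from compound 1 to compound 3 or from compound 2 to compound 3, since all three values are limits: the limit of > 25000 nM in this assay, at which 3 of the 3 values shown sit. From the compounds shown here alone, the effect of methoxy in place of hydrogen on an aromatic carbon remains open.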